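The source may report more compounds than this note shows. Statements on the series, on what has been measured and on what is new or still open speak of the compounds shown alone.

Compound 1 `CCCCCCCCCCCCCCCCCCNC(=O)[C@@H](NC(=O)c1cc2ccccc2o1)[C@@H](C)O` and compound 2 `CCCCCCCCCCCCCCCCCCNC(=O)[C@@H](NC(=O)c1nccc2ccccc12)[C@@H](C)O` share one core and differ only in the aromatic group that sits on the carbonyl carbon. In a functional assay on A-431 cells (Homo sapiens) for cytotoxicity, read by MTT assay, with a stated time of 48 h (a lower number here means a stronger inhibitor, a higher number a weaker inhibitor), compound 1 gives 78800 nM and compound 2 gives 44100 nM. Among the measured compounds shown here, the one measured step between them, a 1.8-fold lower number from compound 1 to compound 2 (0.25 log units; within the scatter), is too small to mean anything, so compound 2 holds the lower of the two numbers without being separable from compound 1, its only neighbour. Compound 3 `CCCCCCCCCCCCCCCCCCNC(=O)[C@@H](NS(=O)(=O)c1ccc(C)cc1)[C@@H](C)O` now changes the core in a different way: (4-methylphenyl)sulfonyl in place of (isoquinolin-1-yl)carbonyl on an amine nitrogen. No measured step speaks to a swap of this kind; the only step shown, a 1.8-fold lower number from compound 1 to compound 2 (0.25 log units; within the scatter), exchanged one aromatic group for another on a carbonyl carbon and stayed inside the scatter, while here the carbonyl itself gives way to a sulfonyl. With nothing pointing up or down, the step is estimated to stay within the scatter, a 1.1-fold higher number from compound 2 to compound 3 (0.05 log units; within the scatter), though the range is kept wide. Compound 3 is therefore expected to give about 50000 nM in this assay, somewhere between 15000 nM and 160000 nM.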

Compound 3, half-maximal inhibitory concentration: 34000 nM
Compound 3: middle estimate off by 1.5-fold (0.17 log units), on the high side; the range from low to high includes it.
By their numbers in this assay, from the lowest: compounds 3, 2 and 1 (each within the scatter of the next, the first and the last beyond it).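

At this amine nitrogen, a sulfonyl can take the place of a carbonyl, and a group with one aromatic ring can replace one with two, while the result in this assay stays inside the scatter: a 1.3-fold lower number from compound 2 to compound 3 (0.11 log units; within the scatter). Among the compounds shown here, the comparison with the other carbonyl compound gives the first step in this short series to pass the scatter, a 2.3-fold lower number from compound 1 to compound 3 (0.37 log units; beyond the scatter), although it is only modest and says little on its own about sulfonyl against carbonyl. No supporting data are available to explain either step.

The compounds shown leave open whether the number depends on the sulfonyl link itself or on the group it carries, which a sulfonyl bearing a methyl or a 4-aminophenyl group in place of the 4-methylphenyl could help to separate. They also leave open what happens when this amine nitrogen carries a simple hydrogen or a plain ethyl group, with neither a carbonyl nor a sulfonyl attached, and so whether either link is needed at all.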